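The compounds below may be only part of what the source reports. "The series", "measured", "known", "first", "only" and "open" are said of these compounds alone.

Compound 1 `CC(C)c1ccccc1OCC(C)N1CCC(NS(=O)(=O)c2cccc(F)c2)CC1` and compound 2 `CC(C)c1ccccc1OCC(C)N1CCC(NS(=O)(=O)c2ccc(F)cc2)CC1` share one core, while compound 3 `CC(C)c1ccccc1OCC(O)CN1CCC(NS(=O)(=O)c2cccc(F)c2)CC1` is built on a different core; how the two cores differ is not broken down here. In an assay on HEK293 cells for displacement of a labelled ligand from 5-hydroxytryptamine receptor 7 (Homo sapiens), read by scintillation counting, with a stated time of 1 h (on this read-out lower numbers stand for stronger inhibition and higher numbers for weaker inhibition), compound 1 gives 170 nM, and in this assay compound 2 gives 74 nM. The change from compound 1 to compound 2 is 4-fluorophenyl in place of 3-fluorophenyl on a sulfonyl sulfur, and it made a 2.3-fold lower number from compound 1 to compound 2 (0.36 log units; beyond the scatter). In this assay compound 3 gives 213 nM; this number and that of compound 1 lie within the scatter of each other, while compound 2 stands at a lower number than compound 3 by more than the scatter. Compound 4 `CC(C)c1ccccc1OCC(O)CN1CCC(NS(=O)(=O)c2ccc(F)cc2)CC1` has not yet been measured. It arises from compound 3 by 4-fluorophenyl in place of 3-fluorophenyl on a sulfonyl sulfur, the same change that turned compound 1 into compound 2, made at a place described in the same words. Among the compounds here this change has been measured only once, so the expectation for compound 4 rests on that single step. Because a 2.3-fold lower number from compound 1 to compound 2 (0.36 log units; beyond the scatter) was a modest step beyond the scatter, a step of similar size is expected in this assay, namely a 2.2-fold lower number from compound 3 to compound 4 (0.35 log units; beyond the scatter), with the caveat that a different core may not answer the same way. Compound 4 is therefore estimated at 95 nM, with a likely range from 50 nM to 200 nM.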

Compound 4, inhibition constant: 104 nM
For compound 4 the middle estimate is 1.1-fold (0.04 log units) below the measured one, and the stated range covers the measured number.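

Putting 4-fluorophenyl in place of 3-fluorophenyl on the sulfonyl sulfur of compound 3 gave a 2.0-fold lower number from compound 3 to compound 4 (0.31 log units; beyond the scatter) in this assay. Set beside the earlier step, this shows that the change carried over between the two cores, with much the same size on each: the same change on two cores in this assay, a 2.3-fold lower number (0.36 log units; beyond the scatter) from compound 1 to compound 2 and a 2.0-fold lower number (0.31 log units; beyond the scatter) from compound 3 to compound 4, 1.1-fold (0.05 log units) apart, within the scatter of two such steps This is still only one pair of steps on two cores in a single assay, so it does not show that the change would behave the same way on a third core, and it does not explain why the 4-fluorophenyl compounds give the lower numbers.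

The compounds shown leave open what other groups on the sulfonyl sulfur would do, such as a plain phenyl, a thienyl or a pyridyl group, since only the two fluorophenyl groups appear here. They also leave open whether the same step would appear on a core with a longer chain, or on one with an amide in place of the sulfonamide.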